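This account rests on a few compounds, and the source may have more. Where it says the series, first, only, none or still open, it means among the compounds named here.

Two compounds built on the same core have been examined in a functional assay on UACC-257 cells (Homo sapiens) for inhibition, read by sulforhodamine B assay, with a stated time of 48 h; on this read-out lower numbers stand for higher toxicity in this test and higher numbers for lower toxicity in this test. Among the compounds with values here, compound 1 `COc1ccc(CNc2nc3cc(N)cc(N)c3nc2-c2ccccc2)cc1` is the one with a plain number: in this assay compound 1 gives 56200 nM. Compound 2 `COc1ccc(Sc2nc3cc(N)cc(N)c3nc2-c2ccccc2)cc1` differs from compound 1 in the link between the shared core and the 4-methoxyphenyl group. For compound 2 this assay reports only a limit, < 100000 nM, and not a number. That is the point described by the limit of < 100000 nM in this assay, at which 1 of the 2 values shown sits. Within the data shown here, with no measured step between the two, the limit for compound 2 and the value of compound 1 can only be set side by side, and the limit does not rule out a value for compound 2 close to that of compound 1.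

The next compound, compound 3 `Nc1cc(N)c2nc(-c3ccccc3)c(Sc3ccc(F)cc3)nc2c1`, differs from compound 2 by fluoro in place of methoxy on an aromatic carbon. Among the measured compounds shown here, no measured pair shows this exchange, so its effect is unknown. Since compound 2 is known only as a limit, no change beyond the scatter is expected from compound 2 to compound 3, and the expected step is a step that the limit leaves unreadable from compound 2 to compound 3. Compound 3 is therefore estimated at about 45000 nM in this assay, within a range from 15000 nM to 95000 nM.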

Compound 3, concentration lethal to 50% of the cells: 60300 nM
Compound 3: middle estimate off by 1.3-fold (0.13 log units), on the low side; measured number inside the range.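

Within the data shown here, no step from compound 2 to compound 3 can be read in this assay, as compound 2 is known there only as a limit. The compounds shown leave open whether fluoro in place of methoxy, or the change of link between compound 1 and compound 2, moves the value beyond the usual scatter.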